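Swapping fluoro for methyl on an inactive piperidine amide

A few compounds are considered here, and "the series" means these few. Any claim that something is new, unique, unknown or untested is made for them only; others in the source may bear on it.

The study rests on an assay on isolated protein for inhibition of vitamin D3 receptor (Homo sapiens), read by fluorescence polarization; on this read-out higher numbers stand for weaker inhibition and lower numbers for stronger inhibition. Compound 1 (`CS(=O)(=O)c1ccc(C(=O)N2CCC(C(=O)N3CCN(c4ccc(F)cc4)CC3)CC2)cc1[N+](=O)[O-]`) gives only a limit in this assay, > 60000 nM. Compound 2 (`CN(Cc1ccccc1)C(=O)C1CCN(C(=O)c2ccc(S(C)(=O)=O)c([N+](=O)[O-])c2)CC1`) likewise gives a limit, > 60000 nM. Compound 3 (`CS(=O)(=O)c1ccc(C(=O)NCC(=O)N(Cc2ccccc2)Cc2ccccc2)cc1[N+](=O)[O-]`) also gives a limit, > 60000 nM. Since every value shown is a limit, as the limit of > 60000 nM in this assay, at which 3 of the 3 values shown sit, records, compound 1 cannot be placed above or below its companions; it simply stands where they stand, at the edge of what the assay reports. Within the data shown here, no step between two measured compounds can be drawn from these data.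

Compound 4 (`Cc1ccc(N2CCN(C(=O)C3CCN(C(=O)c4ccc(S(C)(=O)=O)c([N+](=O)[O-])c4)CC3)CC2)cc1`) is not yet measured. It differs from compound 1 by methyl in place of fluoro on an aromatic carbon, para to a large group. Among the measured compounds shown here, because the only guide is the limit of > 60000 nM in this assay, at which 3 of the 3 values shown sit, no step beyond the scatter in either direction is expected. The expected step is a number no higher from compound 1 to compound 4 (the limit leaves the size open). Compound 4 is expected to give 60000 nM, within a range from 20000 nM to 200000 nM, most probably again as a limit.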

Compound 4, half-maximal inhibitory concentration: > 60000 nM
Compound 4: only a limit was reported (the forecaster's own chance of this, stated with the estimate: 85%); the middle value sits exactly at the limit.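

Compound 4 gives > 60000 nM in this assay, and this value is a limit. No step from compound 1 to compound 4 can be read, because both stop at the same edge: the limit of > 60000 nM in this assay, at which 4 of the 4 values shown sit.

The compounds shown leave open what, if anything, would give a measurable value in this assay.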